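Side-chain change on the shared core: tolerance notes

The source may report more compounds than this note shows. Statements on the series, on what has been measured and on what is new or still open speak of the compounds shown alone.

compound 1 `COc1ccc2[nH]c(C(=O)N3CC(=O)N(Cc4ccccc4)[C@@H](CCc4ccccc4)C3)cc2c1`: > 30000 nM (a limit)
compound 2 `COc1ccc2[nH]c(C(=O)N3CC(=O)N(Cc4ccccc4)[C@@H](N4CCc5ccccc54)C3)cc2c1`: > 100000 nM (a limit)
compound 3 `COc1ccc2[nH]c(C(=O)N3CC(=O)N(Cc4ccccc4)[C@@H](CN4CCN(c5ccccn5)CC4)C3)cc2c1`: > 30000 nM (a limit)

All three readings in an ADME assay on Vero cells (Chlorocebus sabaeus) for cytotoxicity, with a stated time of 7 days (a higher number here means that more compound is tolerated, a lower number that less compound is tolerated), are limits and not numbers. Compound 3 stands at the limit > 30000 nM and so has no exact place in the series.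

The next change leads to compound 4 `COc1ccc2[nH]c(C(=O)N3CC(=O)N(Cc4ccccc4)[C@@H](CN4CC5CCCC5C4)C3)cc2c1`. On a saturated chain carbon bound to a saturated ring carbon, the difference is a group of 8 heavy atoms (7 carbon, 1 nitrogen; one five-membered non-aromatic ring of carbon only, one five-membered non-aromatic ring with 1 hetero atom) in place of a group of 12 heavy atoms (9 carbon, 3 nitrogen; one six-membered non-aromatic ring with 2 hetero atoms, one six-membered aromatic ring with 1 hetero atom), on a saturated chain carbon bound to a saturated ring carbon.

Within the data shown here, two measured steps bear on this. The closer is a step that the two limits leave unreadable from compound 1 to compound 3, made at the same place. The other is a step that the two limits leave unreadable from compound 1 to compound 2, made on a saturated ring carbon. Neither has a readable size, so no size can be carried over to the new step.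

Compound 3 gives only the limit > 30000 nM, and no step beyond the scatter is expected from it. Another limit is the likeliest reading in this assay.

The expected change is a step that the limit leaves unreadable from compound 3 to compound 4.

For compound 4 the estimated value is 40000 nM, with an expected range of 15000 nM to 100000 nM.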

Compound 4, half-maximal cytotoxic concentration: 10600 nM
The estimate for compound 4 lay 3.8-fold (0.58 log units) above the measured number, and the stated range ends above it.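

Compound 4 gives the series its first reading in this assay that is a number and not a limit, and it shows that the side chain can lower tolerance on the shared core: the change at this place gives an at least 2.8-fold lower number from compound 3 to compound 4 (0.45 log units; beyond the scatter). The drop also holds against the other two compounds, with an at least 2.8-fold lower number from compound 1 to compound 4 (0.45 log units; beyond the scatter) at the same place and an at least 9.4-fold lower number from compound 2 to compound 4 (0.97 log units; beyond the scatter) where the group sits on a saturated ring carbon. Compound 4 is also the only compound shown whose varied group has no aromatic ring, though a single compound sets no pattern.

On these data alone, whether the missing aromatic ring or some other feature of the new group goes with the lower number remains open. How a diethylamino group or a carboxylic acid on the same saturated chain carbon would read in this assay is also unknown.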